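Removing the sulfanyl from compound 2

The source may hold more compounds than are shown below. What is called first, only, known or untested is meant among the compounds shown, and "the series" means these compounds.

For the measured compounds named here, compound 2 `Cc1nc2c3ccccc3ccc2c2nc3c(ccc4ccccc43)c(-c3ccccc3S)c12` is the only compound of the pair with a numerical result in a functional assay on HeLa cells (Homo sapiens) for cytotoxicity, read by MTT assay, with a stated time of 48 h (on this read-out lower numbers stand for stronger inhibition and higher numbers for weaker inhibition), where compound 2 gives 3190 nM. Compound 1 `Cc1nc2c3ccccc3ccc2c2nc3c(ccc4ccccc43)c(-c3ccccc3Cl)c12` instead sits at a limit of the assay, > 80000 nM. Going by the values given here, the single measured step, an at least 25-fold lower number from compound 1 to compound 2 (1.39 log units; beyond the scatter), bears on the change hydrogen in place of sulfanyl on an aromatic carbon that produces compound 3 `Cc1nc2c3ccccc3ccc2c2nc3c(ccc4ccccc43)c(-c3ccccc3)c12`, as chloro and hydrogen alike lack the sulfanyl. Compound 3 is therefore expected to shift toward a higher number, by roughly a 9.4-fold higher number from compound 2 to compound 3 (0.97 log units; beyond the scatter), with a real chance of reaching the limit (the limit of > 80000 nM in this assay, at which 1 of the 2 values shown sits). Compound 3 is estimated at 30000 nM, within 6000 nM to 80000 nM.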

Compound 3, half-maximal inhibitory concentration: > 80000 nM
Compound 3 gave a limit, no number (the forecaster's own chance of this, stated with the estimate: 35%); middle value at least 2.6-fold (0.42 log units) from the limit.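

In this assay, for the compounds shown here, replacing the sulfanyl with hydrogen gives an at least 25-fold higher number from compound 2 to compound 3 (1.39 log units; beyond the scatter), so a numerical result in this small set is seen only with sulfanyl at this position, with neither hydrogen nor chloro in its place. Compound 1 and compound 3 each give a limit rather than a number, so the step between them cannot be read and hydrogen and chloro cannot be ordered: the limit of > 80000 nM in this assay, at which 2 of the 3 values shown sit.

As far as these compounds go, whether a hydroxyl, an amine or a methylsulfanyl group on the same aromatic carbon would give a number remains open. Also open, from the compounds shown here alone, is whether sulfanyl elsewhere on the phenyl ring would give a number.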